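The compounds below may be only part of what the source reports. "The series", "measured", "known", "first", "only" and "open" are said of these compounds alone.

Compound 1, whose structure is `COc1ccc(/C=N/NC(=S)NC(C)(C)[C@H]2CC=C(C)CC2)cc1`, carries a 4-methoxyphenyl group on the carbon that is double-bonded to nitrogen. In a functional assay on 786-0 cells (Homo sapiens) for inhibition, read by sulforhodamine B assay, with a stated time of 48 h (on this read-out lower numbers stand for stronger inhibition of growth and higher numbers for weaker inhibition of growth), compound 1 gives 8900 nM. Among the measured compounds shown here, this is the only number available in this assay; the one other value is not a number but a limit. That other value belongs to compound 2, whose structure is `CC1=CC[C@H](C(C)(C)NC(=S)N/N=C/c2cccc([N+](=O)[O-])c2)CC1`. In this assay compound 2 reaches only the limit > 100000 nM, which is the limit described in the limit of > 100000 nM in this assay, at which 1 of the 2 values shown sits. Compound 1 therefore stands alone as the single measured point, with nothing beyond the scatter to compare against.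

Compound 3, whose structure is `CC1=CC[C@H](C(C)(C)NC(=S)N/N=C/c2ccco2)CC1`, has not yet been measured. It differs from compound 1 in one place, namely (furan-2-yl in place of 4-methoxyphenyl on a carbon with a double bond to nitrogen), in words furan-2-yl in place of 4-methoxyphenyl on a carbon with a double bond to nitrogen. For the measured compounds named here, no two measured compounds differ in only one place, so no measured step shows what such a swap does in this assay. The step from compound 1 to compound 3 is expected to be a 1.7-fold higher number from compound 1 to compound 3 (0.23 log units; within the scatter), a modest weakening at most and possibly nothing beyond the scatter. Compound 3 is estimated to give 15000 nM in this assay, within a range from 4000 nM to 60000 nM.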

Compound 3, concentration for 50% growth inhibition: 11700 nM
Beside the measured number, compound 3's estimate is 1.3-fold (0.11 log units) above it; low and high end bracket the measured number.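

In this assay, the swap on the carbon with a double bond to nitrogen now has a measured step, which replaces 4-methoxyphenyl with furan-2-yl and gives a 1.3-fold higher number from compound 1 to compound 3 (0.12 log units; within the scatter). At this place, then, a six-membered aromatic ring of carbon only and a smaller five-membered aromatic ring with a hetero atom cannot be told apart in this growth read-out, so the larger ring and its methoxy group are not needed to keep the activity seen with compound 1. That tolerance covers only compound 1 and compound 3 and does not extend to every aromatic group, since compound 2, which goes against any wider pattern, is recorded as a limit and not as a number: the limit of > 100000 nM in this assay, at which 1 of the 3 values shown sits.

The compounds shown leave open whether a plain phenyl ring, a pyridine ring or a phenyl ring carrying an amine would fit with compound 1 and compound 3 or fall away as compound 2 does. They also give no measured property that would explain why some groups at this place keep the activity, so the reason for the difference remains unknown.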